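Swapping an aryl amine for piperazine on a shared core

This account rests on a few compounds, and the source may have more. Where it says the series, first, only, none or still open, it means among the compounds named here.

Measured compounds:
- compound 1, `N#Cc1c(Cl)nc(SCc2nc3ccccc3[nH]2)nc1-c1ccccc1`, 3.28 nM
- compound 2, `N#Cc1c(Nc2ccccc2)nc(SCc2nc3ccccc3[nH]2)nc1-c1ccccc1`, 8.9 nM
- compound 3, `N#Cc1c(Nc2ccccn2)nc(SCc2nc3ccccc3[nH]2)nc1-c1ccccc1`, 8.9 nM

In a functional assay on SK-MEL-28 cells (Homo sapiens) for cytotoxicity, read by MTT assay, with a stated time of 3 days (a lower number here means a stronger inhibitor, a higher number a weaker inhibitor), compound 3 stands level with compound 2, the two sharing the highest numbers of the three; compound 1 gives the lowest number, and the step of a 2.7-fold higher number from compound 1 to compound 3 (0.43 log units; beyond the scatter) lies beyond the scatter, while the step of no change at the digits printed from compound 2 to compound 3 (within the scatter) lies within it.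

Compound 4, `N#Cc1c(-c2ccccc2)nc(SCc2nc3ccccc3[nH]2)nc1N1CCNCC1`, has not yet been measured in this assay. It differs from compound 3 in one place: piperazin-1-yl in place of (pyridin-2-yl)amino on an aromatic carbon.

For the measured compounds named here, the steps that bear on this change are a 2.7-fold higher number from compound 1 to compound 2 (0.43 log units; beyond the scatter) and a 2.7-fold higher number from compound 1 to compound 3 (0.43 log units; beyond the scatter), both modest, and no change at the digits printed from compound 2 to compound 3 (within the scatter), which shows that exchanging the aryl group on the amine nitrogen made no difference. Going by the values given here, no measured step exchanges an amine for piperazin-1-yl, so the expectation rests on the observation that the two amino-bearing compounds sit close together. Compound 4 is therefore expected to stay near compound 3, with a step of a 1.1-fold higher number from compound 3 to compound 4 (0.05 log units; within the scatter). The estimate for compound 4 is 10 nM, within a range from 4 nM to 30 nM.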

Compound 4, half-maximal inhibitory concentration: 2.6 nM
The estimate for compound 4 lay 3.8-fold (0.59 log units) above the measured number, outside the stated range (below it).
By their numbers in this assay, from the lowest: compounds 4 and 1 (each within the scatter of the next); then compounds 2 and 3 (each within the scatter of the next).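

In this assay the identity of the amine at this position does matter, which the matching values of the two aryl amines could not show: piperazin-1-yl, with its six-membered non-aromatic ring, gives lower numbers than (pyridin-2-yl)amino (a 3.4-fold lower number from compound 3 to compound 4 (0.53 log units; beyond the scatter)) and anilino (a 3.4-fold lower number from compound 2 to compound 4 (0.53 log units; beyond the scatter)). Replacing chloro with piperazin-1-yl, by contrast, stays within the scatter (a 1.3-fold lower number from compound 1 to compound 4 (0.10 log units; within the scatter)), so among the amines shown, only the two aryl amines sit apart from chloro. No measurement here explains why the ring amine and the aryl amines differ.

From the compounds shown here alone, whether a morpholin-4-yl group or an open-chain amine such as dimethylamino would stay level with compound 4 or sit with compound 3 remains open. So does the effect of a methyl group on the free nitrogen of the piperazine.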